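From benzyl(methyl)amino to 1,2,3,4-tetrahydroisoquinolin-2-yl on a sulfonyl sulfur

The compounds below may be only part of what the source reports. "The series", "measured", "known", "first", "only" and "open" are said of these compounds alone.

Values in an ADME assay on the whole organism (Mus musculus) for pharmacokinetics, at a dose of 10 mg/kg by the oral route; a lower number here means that a smaller share of the oral dose reaches the circulation, a higher number that a larger share of the oral dose reaches the circulation:
Compound 1 `CN(Cc1ccccc1)S(=O)(=O)c1ccc(NC(=O)NCc2ccncc2)cc1`: > 100%
Compound 2 `O=C(NCc1cn[nH]c1)Nc1ccc(S(=O)(=O)c2ccc(Cl)cc2)cc1`: 80%
Compound 3 `O=C(NCc1cnco1)Nc1ccc(S(=O)(=O)c2cccc(OC(F)(F)F)c2)cc1`: > 100%

Compound 1 stands at > 100%, which is a limit of the assay and not a number. Compound 3 gives > 100%, which is also a limit. Compound 1 therefore sits at the limit of > 100% in this assay, at which 2 of the 3 values shown sit. Compound 2 alone gives a number, 80%.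

Compound 4 `O=C(NCc1ccncc1)Nc1ccc(S(=O)(=O)N2CCc3ccccc3C2)cc1` has yet to be measured in this assay. It keeps the core of compound 1 and differs in one place: 1,2,3,4-tetrahydroisoquinolin-2-yl in place of benzyl(methyl)amino on a sulfonyl sulfur. Among the compounds with values here, no two measured compounds differ in one place only, so the effect of such an exchange has not been seen directly. Compound 1 offers only a limit. A small fall is expected, since compound 2 shows a number of 80%. The expected change is a number at least 10 percentage points lower from compound 1 to compound 4 (that floor lies within the scatter), and it is not expected to go far beyond the scatter. For compound 4 the estimate is 90%, with an expected range from 55% to 115%.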

Compound 4, oral bioavailability: 47%
Estimate against measurement, compound 4: 43 percentage points above; the measured number lies below the stated range.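

In this assay, within the data shown here, this is the first single exchange that can be read directly: 1,2,3,4-tetrahydroisoquinolin-2-yl in place of benzyl(methyl)amino on a sulfonyl sulfur gives a number at least 53 percentage points lower from compound 1 to compound 4 (beyond the scatter). Compound 1 gives > 100%, which is a limit of the assay and not a number, so the step is only a floor on the fall: the limit of > 100% in this assay, at which 2 of the 4 values shown sit. The read-out therefore responds strongly to the group at this position, even though the two groups match in hydrogen-bond donors, hydrogen-bond acceptors and net charge, and the entering group differs by one further non-aromatic ring.

One pair cannot show whether the ring itself accounts for the fall. As far as these compounds go, whether a piperidine or a morpholine on the sulfonyl sulfur would stay nearer compound 4 or compound 1 remains open, and compounds 2 and 3 offer no single-place comparison to settle it.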